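A Ring Spacer Change on the Piperidine Nitrogen

The source may hold more compounds than are shown below. What is called first, only, known or untested is meant among the compounds shown, and "the series" means these compounds.

Measured compounds:
compound 1 `CC(C)c1nc(C(=O)NCC2(O)CCN(CC(C)(C)O)CC2)c2ccccn12` — 72.3 nM
compound 2 `CC(C)c1nc(-c2nnc(C3CCN(C4CCC4)CC3)o2)c2ccccn12` — 840 nM

In a functional assay on CHO cells for agonist activity at 5-hydroxytryptamine receptor 4 (Homo sapiens), read by a luciferase reporter and cAMP accumulation, with a stated time of 4 h (a higher number here means that more compound is needed for the effect, a lower number that less compound is needed), compound 1 gives 72.3 nM, while compound 2 gives 840 nM. Of the two numbers seen so far, compound 2 stands at the higher one, and the gap to compound 1 lies beyond the usual scatter of the measurement, so compound 2 needs clearly more material than compound 1 for the same effect.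

Compound 3 `CC(C)c1nc(-c2nnc(C3CCN(CC4CCC4)CC3)o2)c2ccccn12` has not yet been measured. It differs from compound 2 in one place: cyclobutylmethyl in place of cyclobutyl on an amine nitrogen in a ring. For the measured compounds named here, no measured pair differing only in this way is available, so the size of the step can only be guessed. Since the rest of the molecule is unchanged, a small move in either direction, possibly within the scatter, seems the most likely outcome, with a modest gain slightly favoured.

The expected value of compound 3 is 450 nM, with a range from 120 nM to 2000 nM. That estimate means a step of a 1.9-fold lower number from compound 2 to compound 3 (0.27 log units; within the scatter) is expected.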

Compound 3, half-maximal effective concentration: 520 nM
Beside the measured number, compound 3's estimate is 1.2-fold (0.06 log units) below it; the measured number falls inside the stated range.
By their numbers in this assay, from the lowest: compound 1; then compounds 3 and 2 (each within the scatter of the next).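

On the amine nitrogen of the six-membered non-aromatic ring, replacing cyclobutyl with cyclobutylmethyl gives a 1.6-fold lower number from compound 2 to compound 3 (0.21 log units; within the scatter) in this assay. For the compounds shown here, this is the first comparison that isolates a single change at this nitrogen, and it shows that this change leaves the number within the normal variation of the measurement, so compound 2 and compound 3 cannot be told apart here. No supporting measurement bears on this result, so the pair gives the size of the step but no explanation for it.

Compound 1 gives 72.3 nM but differs from compound 2 and compound 3 in more than one place, so its gap to them says nothing about the substituent on this nitrogen. Going by these compounds, it remains open whether a longer chain such as cyclobutylethyl, a larger ring such as cyclohexylmethyl, or a carboxylic acid carried on this nitrogen would move the number beyond the scatter, since a single step within the scatter does not show how far this position's tolerance extends.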